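Acetyl on the chain: compound 2 to compound 3

The source may hold more compounds than are shown below. What is called first, only, known or untested is meant among the compounds shown, and "the series" means these compounds.

In a functional assay on U-373MG ATCC cells (Homo sapiens) for inhibition, read by MTT assay, with a stated time of 72 h (on this read-out lower numbers stand for stronger inhibition of growth and higher numbers for weaker inhibition of growth), compound 1 `CC(C)(C)OC(=O)/C=C/C1=CC[C@H]2C(C)(C)CCC[C@]2(C)[C@H]1C=O` gives 40000 nM and compound 2 `COC(=O)/C=C/C=C/C1=CC[C@H]2C(C)(C)CCC[C@]2(C)[C@H]1C=O` gives 27000 nM. Going by the values given here, compound 2 therefore stands within the scatter of compound 1, the only other measured member of the series, and the two numbers cannot be ranked. Compound 3 `CC(=O)/C=C/C1=CC[C@H]2C(C)(C)CCC[C@]2(C)[C@H]1C=O` keeps the shared core and carries acetyl in place of 2-(methoxycarbonyl)ethenyl on a double-bonded chain carbon bound to a double-bonded chain carbon. Among the compounds with values here, one measured step bears on this place: a 1.5-fold lower number from compound 1 to compound 2 (0.17 log units; within the scatter). That exchange of tert-butoxycarbonyl for 2-(methoxycarbonyl)ethenyl left the number within the scatter, so no step beyond the scatter is expected in this assay. Within the data shown here, no measured compound carries acetyl, and a single step is thin support, so the range stays wide. The expected step is a 1.1-fold higher number from compound 2 to compound 3 (0.05 log units; within the scatter), with no firm direction. For compound 3 the estimate is 30000 nM, with an expected range of 12000 nM to 70000 nM.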

Compound 3, concentration for 50% growth inhibition: 25000 nM
For compound 3 the middle estimate is 1.2-fold (0.08 log units) above the measured one; low and high end bracket the measured number.
By their numbers in this assay, from the lowest: compounds 3, 2 and 1 (each within the scatter of the next).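

In this assay, the exchange of 2-(methoxycarbonyl)ethenyl for acetyl on a double-bonded chain carbon bound to a double-bonded chain carbon gives a 1.1-fold lower number from compound 2 to compound 3 (0.03 log units; within the scatter), even though the entering group has 3 heavy atoms against 6, one double bond against 2 and one hydrogen-bond acceptor against 2. Compounds 1 and 2 both carry an ester at this place, whereas compound 3 carries a ketone carbonyl, so in this small set the ester oxygen is not needed to keep the number within the scatter. The exchange of tert-butoxy for methyl on a carbonyl carbon gives a 1.6-fold lower number from compound 1 to compound 3 (0.20 log units; within the scatter), which adds a third group at this place and still leaves all three compounds unranked, with no step beyond the scatter yet seen here.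

On these data alone, whether an amine, a carboxylic acid or a longer chain at this place would move the number beyond the scatter remains open, as does whether any group here matters at all for growth inhibition in these cells. Nothing available accounts for the flatness of these numbers.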